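Removing three methyls from an anilide that shows no potency

The source may hold more compounds than are shown below. What is called first, only, known or untested is meant among the compounds shown, and "the series" means these compounds.

Compound 1 `COc1ccc(CS(=O)(=O)CC(=O)Nc2c(C)cc(C)cc2C)cc1[N+](=O)[O-]` — > 30000 nM
Compound 2 `COc1ccc(CS(=O)(=O)CC(=O)Nc2c(C)cc(C)cc2C)cc1N` — > 30000 nM

In a functional assay on MCF7 cells (Homo sapiens) for cytotoxicity, read by MTT assay, with a stated time of 72 h (a higher number here means a weaker inhibitor of growth, a lower number a stronger inhibitor of growth), compound 1 gives only a limit of the assay, > 30000 nM. Compound 2 likewise gives only a limit in this assay, namely > 30000 nM. For the measured compounds named here, the single step connecting them, a step that the two limits leave unreadable from compound 1 to compound 2, therefore has no readable size, and the limit of > 30000 nM in this assay, at which 2 of the 2 values shown sit, records where both values sit. Compound 1 thus stands at the weak end of what the assay reports, with no number of its own.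

Compound 3 `COc1ccc(CS(=O)(=O)CC(=O)Nc2ccccc2)cc1[N+](=O)[O-]` differs from compound 1 by phenyl in place of 2,4,6-trimethylphenyl on an amide-type nitrogen. Going by the values given here, no measured step touches this part of the structure, and the one step that was measured is itself unreadable, so nothing in the data sizes the change ahead. The expected step from compound 1 to compound 3 is a number no higher from compound 1 to compound 3 (the limit leaves the size open), which is expected to leave compound 3 at the limit as well. Compound 3 is therefore estimated at 30000 nM in this assay, with a range from 8000 nM to 100000 nM, a further limit rather than a number being the likelier outcome.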

Compound 3, concentration for 50% growth inhibition: > 30000 nM
Compound 3: only a limit was reported (the forecaster's own chance of this, stated with the estimate: 80%); the middle value lies on the limit itself.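

Compound 3 gives > 30000 nM in this assay, which is a limit of the assay and not a number. Compound 1 and compound 3 thus both rest on limits, and the step between them cannot be read: the limit of > 30000 nM in this assay, at which 3 of the 3 values shown sit. The compounds shown leave open whether any change to the shared core gives a readable potency in this assay.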